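This account rests on a few compounds, and the source may have more. Where it says the series, first, only, none or still open, it means among the compounds named here.

Of the compounds shown here, three have been measured so far, all built on the same core. In an assay on cells for agonist activity at ecdysone receptor (Bombyx mori), read by a luciferase reporter, with a stated time of 24 h (on this read-out higher numbers stand for an effect only at larger amounts of compound and lower numbers for an effect already at smaller amounts), compound 1 `CC(C)(C)N(NC(=O)c1ccccc1)C(=O)c1ccccc1I` gives 105 nM, compound 2 `CC(C)(C)N(NC(=O)c1ccccc1)C(=O)c1ccc(Cl)cc1Cl` gives 117 nM, and compound 3 `Cc1ccccc1C(=O)NN(C(=O)c1ccccc1Cl)C(C)(C)C` gives 72.4 nM, the lowest of the three numbers, although its gaps to compound 1 and compound 2 both lie within the scatter. Within the data shown here, the only single-point step measured, a 1.1-fold higher number from compound 1 to compound 2 (0.05 log units; within the scatter), altered a different aromatic group and stayed within the scatter. Among the measured compounds shown here, compound 4 `Cc1ccc(C(=O)NN(C(=O)c2ccccc2Cl)C(C)(C)C)c(C)c1` differs from compound 3 by methyl in place of hydrogen on an aromatic carbon, a change on the ring that no measured step has touched, so nothing measured bears on it directly. The step expected, a 1.0-fold lower number from compound 3 to compound 4 (0.00 log units; within the scatter), is therefore none beyond the scatter. For compound 4 the estimate is 72 nM, with a range from 30 nM to 175 nM.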

Compound 4, half-maximal effective concentration: 162 nM
For compound 4 the middle estimate is 2.3-fold (0.35 log units) below the measured one; measured number inside the range.
By their numbers in this assay, from the lowest: compounds 3, 1, 2 and 4 (each within the scatter of the next, the first and the last beyond it).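

In this assay, going from 2-methylphenyl to 2,4-dimethylphenyl gives a 2.2-fold higher number from compound 3 to compound 4 (0.35 log units; beyond the scatter), the only step shown that lies beyond the scatter and the only one on this ring. A single methyl para to a large group is thus enough to raise the number here, while the step on the other aromatic group stayed within the scatter. No measured evidence accounts for this shift. Going by these compounds, whether methoxy or an amine at this position would raise the number as well remains open. So does whether methyl would do the same on a ring lacking the other methyl.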